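The compounds below may be only part of what the source reports. "The series", "measured", "known", "first", "only" and "open" are said of these compounds alone.

In a functional assay on KBVIN cells (Homo sapiens) for antiproliferative activity, read by sulforhodamine B assay, with a stated time of 3 days (a higher number here means a weaker inhibitor of growth, a lower number a stronger inhibitor of growth), compound 1 `COc1ccc(NC(=O)c2cccc(Nc3ncc(F)c(Nc4ccc(F)cc4)n3)c2)cc1` gives 15700 nM and compound 2 `O=C(Nc1cccc(Nc2ncc(F)c(Nc3ccc(F)cc3)n2)c1)c1cccc([N+](=O)[O-])c1` gives 11400 nM, two values within the usual scatter of each other. Compound 3 `CN(C)c1ccc(C(=O)Nc2cccc(Nc3ncc(F)c(Nc4ccc(F)cc4)n3)c2)cc1` has no number, only a limit of the assay, > 10000 nM. Compound 4 `O=C(Nc1cccc(Nc2ncc(F)c(Nc3ccc(F)cc3)n2)c1)c1ccccc1` carries hydrogen in place of dimethylamino on an aromatic carbon, para to a large group: hydrogen in place of dimethylamino on an aromatic carbon. Within the data shown here, the one measured step that bears on this change is a step that the limit leaves unreadable from compound 2 to compound 3, so it offers no size to carry over. The closest numerical guide is compound 2 at 11400 nM, so only a modest move is expected, and the expected step, a step that the limit leaves unreadable from compound 3 to compound 4, stays uncertain. For compound 4 the estimate is 12000 nM, expected to fall between 5500 nM and 25000 nM.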

Compound 4, concentration for 50% growth inhibition: > 10000 nM
Compound 4 gave a limit, no number; the forecaster's own chance of this, stated with the estimate: 35%; the middle value lies beyond the limit too.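

Among these compounds, no step to compound 4 from compound 1, compound 2 or compound 3 can be read, since compound 4, like compound 3, gives only a limit: the limit of > 10000 nM in this assay, at which 2 of the 4 values shown sit. Going by these compounds, how strongly compound 3 and compound 4 inhibit growth stays open, and so does what swapping dimethylamino for hydrogen changes.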